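Extending the amine substituent from methyl to heptyl

The compounds below may be only part of what the source reports. "The series", "measured", "known", "first", "only" and "open" are said of these compounds alone.

Measured compounds:
compound 1, `COc1ccc(CCCN2CCC(COC(c3ccc(Br)cc3)c3ccc(Br)cc3)CC2)cc1`, 3200 nM
compound 2, `COc1ccc(CCCN2CCC(CCC(c3ccccc3)c3ccccc3)CC2)cc1`, 200 nM
compound 3, `CN1CCC(COC(c2ccccc2)c2ccccc2)CC1`, > 20000 nM

In a functional assay on cells (T-cell line, Homo sapiens) for inhibition (a lower number here means a stronger inhibitor, a higher number a weaker inhibitor), compound 1 gives 3200 nM and compound 2 gives 200 nM. Compound 3 stands apart from both: its value in this assay is only a limit, > 20000 nM, so no number is known for it, and it sits at the limit of > 20000 nM in this assay, at which 1 of the 3 values shown sits.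

Compound 4, `CCCCCCCN1CCC(COC(c2ccccc2)c2ccccc2)CC1`, is not yet measured. It differs from compound 3 in one place: hexyl in place of hydrogen on a saturated chain carbon bound to an amine nitrogen in a ring. For the measured compounds named here, compounds 1 and 2 carry longer substituents on the same ring nitrogen than compound 3 does and both return numbers rather than limits, while compound 3 does not; no step between them is counted, so this is only what the values show.

For compound 4 an improvement over compound 3 is expected, a step of an at least 8.0-fold lower number from compound 3 to compound 4 (0.90 log units; beyond the scatter) that should carry it beyond the scatter and into the measurable range. Compound 4 is therefore estimated at 2500 nM, with a range from 500 nM to 12000 nM.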

Compound 4, half-maximal inhibitory concentration: 500 nM
For compound 4 the middle estimate is 5.0-fold (0.70 log units) above the measured one; the range from low to high includes it.
By their numbers in this assay, from the lowest: compound 2; then compound 4; then compound 1. At a limit, above all of these: compound 3.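

Replacing methyl with heptyl at this position gives an at least 40-fold lower number from compound 3 to compound 4 (1.60 log units; beyond the scatter) in this assay. This is the first pair among the compounds shown that differs in only one place, so a change in the substituent on the amine nitrogen in the ring can now be tied directly to a change in the read-out, which compounds 1 and 2 could not do because they also differ elsewhere. The true size of the step remains unknown, and only its lower bound can be given, because the value for compound 3 is a limit: the limit of > 20000 nM in this assay, at which 1 of the 4 values shown sits.

On these data alone, a single pair cannot show how the value follows chain length, so it remains open whether a butyl chain would give a step of similar size. As far as these compounds go, it also remains open whether a benzyl group or a heptyl chain ending in a carboxylic acid would be tolerated on the same nitrogen.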